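Series notes: ester in place of the difluorobenzyl arm

A few compounds are considered here, and "the series" means these few. Any claim that something is new, unique, unknown or untested is made for them only; others in the source may bear on it.

Among the measured compounds shown here, compound 3 `CCN(CC)c1ccc2cc(C(=O)c3ccc(N4CCN(C(=O)CN5CCN(Cc6ccc(F)c(F)c6)CC5)CC4)cc3)oc2c1` holds the only number so far: in a functional assay on MCF7 cells (Homo sapiens) for cytotoxicity, read by MTT assay, with a stated time of 48 h (on this read-out lower numbers stand for stronger inhibition and higher numbers for weaker inhibition), compound 3 gives 9220 nM. Compound 1 `CCN(CC)c1ccc2cc(C(=O)c3ccc(N4CCN(C(=O)CN5CCN(S(=O)(=O)C6CC6)CC5)CC4)cc3)oc2c1` returns a limit, > 40000 nM. Compound 2 `CCN(CC)c1ccc2cc(C(=O)c3ccc(N4CCN(C(=O)CN5CCN(S(=O)(=O)c6ccc(C#N)cc6)CC5)CC4)cc3)oc2c1` likewise returns a limit, > 40000 nM, so the step that the two limits leave unreadable from compound 1 to compound 2 cannot be read. Against these, an at least 4.3-fold lower number from compound 1 to compound 3 (0.63 log units; beyond the scatter) and an at least 4.3-fold lower number from compound 2 to compound 3 (0.63 log units; beyond the scatter) both run toward the lower number; each puts a 3,4-difluorobenzyl in place of a sulfonyl group on the ring amine nitrogen, and each rests on (the limit of > 40000 nM in this assay, at which 2 of the 3 values shown sit), so its full size stays open.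

Compound 4 `CCOC(=O)CN1CCN(CC(=O)N2CCN(c3ccc(C(=O)c4cc5ccc(N(CC)CC)cc5o4)cc3)CC2)CC1` is the next step from compound 3: ethoxycarbonyl in place of 3,4-difluorophenyl on a saturated chain carbon bound to an amine nitrogen in a ring. For the measured compounds named here, no measured pair removes the 3,4-difluorophenyl while the amine nitrogen keeps its saturated chain carbon, so nothing on hand speaks to this change directly. Going by the values given here, the two readable steps into compound 3 show only that the difluorobenzyl arm goes with the one number below the limit. The expectation for compound 4 in this assay is therefore a higher number, a 3.3-fold higher number from compound 3 to compound 4 (0.51 log units; beyond the scatter), with a real chance of a limit. Compound 4 is estimated at 30000 nM, between 8000 nM and 80000 nM.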

Compound 4, half-maximal inhibitory concentration: > 40000 nM
Compound 4 gave a limit, no number (the forecaster's own chance of this, stated with the estimate: 50%); middle value at least 1.3-fold (0.12 log units) from the limit.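

In this assay, ethoxycarbonyl in place of 3,4-difluorophenyl, with the saturated chain carbon kept on the ring amine nitrogen, gives an at least 4.3-fold higher number from compound 3 to compound 4 (0.63 log units; beyond the scatter) and so tests that aryl group directly. The lower number of compound 3 therefore does not follow from merely having a non-sulfonyl arm on this nitrogen, since compound 4, which also has no sulfonyl group, returns a limit. Going by these compounds, the steps from compound 1 and compound 2 to compound 4 join two limits and cannot be read, and the full size of the step from compound 3 stays open: the limit of > 40000 nM in this assay, at which 3 of the 4 values shown sit.

The compounds shown do not separate the contribution of the phenyl ring from that of its two fluorines, which a plain benzyl on the same nitrogen would address. They also leave open whether a carboxylic acid or a primary amide in place of the ethyl ester would stay at the limit.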